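A Swap at the Far End of the Chain

The compounds below may be only part of what the source reports. "The series", "measured", "known", "first", "only" and "open" are said of these compounds alone.

In an assay for inhibition of Indoleamine 2,3-dioxygenase 1 (Homo sapiens), read by fluorescence, with a stated time of 24 h (on this read-out lower numbers stand for stronger inhibition and higher numbers for weaker inhibition), compound 2 `CS(=O)(=O)CC(=O)NCCSc1nonc1/C(=N/O)Nc1ccc(F)c(C(F)F)c1` gives 14 nM. Compound 1 `CSc1nonc1/C(=N/O)Nc1ccc(F)c(Br)c1` gives 15 nM in this assay, and the two numbers lie within the usual scatter of each other. Compound 3 `CC(C)(O)CC(=O)NCCSc1nonc1/C(=N/O)Nc1ccc(F)c(C(F)F)c1` differs from compound 2 by 1-hydroxy-1-methylethyl in place of methylsulfonyl on a saturated chain carbon bound to a carbonyl carbon, a change on a saturated chain carbon bound to a carbonyl carbon. Among the compounds with values here, no measured pair shows this change, so the step from compound 2 to compound 3 is estimated as a 1.1-fold higher number from compound 2 to compound 3 (0.03 log units; within the scatter), with no clear direction beyond the scatter. Compound 3 is therefore expected to give about 15 nM, within a range from 6 nM to 40 nM.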

Compound 3, half-maximal inhibitory concentration: 8.4 nM
Compound 3: the middle estimate sits 1.8-fold (0.25 log units) above what was measured; low and high end bracket the measured number.
By their numbers in this assay, from the lowest: compounds 3, 2 and 1 (each within the scatter of the next).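

In this assay, within the data shown here, 1-hydroxy-1-methylethyl in place of methylsulfonyl gives a 1.7-fold lower number from compound 2 to compound 3 (0.22 log units; within the scatter), the first measured step at this saturated chain carbon bound to a carbonyl carbon. The position therefore accepts this exchange, in which a group with no hydrogen-bond donor gives way to one that has a hydrogen-bond donor, with no shift beyond the scatter. No measurement here explains why the two groups give such similar numbers. As far as these compounds go, whether an amine, a carboxylic acid or a longer chain would fit as well stays open.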